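The compounds below may be only part of what the source reports. "The series", "measured", "known", "first", "only" and "open" are said of these compounds alone.

Measured in a functional assay on PC-3 cells (Homo sapiens) for antiproliferative activity, read by MTT assay, with a stated time of 48 h; a higher number here means a weaker inhibitor, a lower number a stronger inhibitor:
- Compound 1 `c1ccc(-c2nnc(-c3cn4ccccc4n3)o2)cc1`: 22200 nM
- Compound 2 `Clc1ccc(-c2nnc(-c3cn4ccccc4n3)o2)cc1`: 33700 nM
- Compound 3 `Brc1ccc(-c2nnc(-c3cn4ccccc4n3)o2)cc1`: > 50000 nM (a limit of the assay, not a number)

Among the measured compounds shown here, compound 1 and compound 2 hold the only two exact numbers, and they lie within the scatter of each other. Chloro in place of hydrogen gives a 1.5-fold higher number from compound 1 to compound 2 (0.18 log units; within the scatter). Bromo in place of hydrogen gives an at least 2.2-fold higher number from compound 1 to compound 3 (0.35 log units; beyond the scatter), and that comparison rests on a limit.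

Compound 4 `Cc1cccn2cc(-c3nnc(-c4ccccc4)o3)nc12` keeps the core of compound 1 and differs in one place: methyl in place of hydrogen on an aromatic carbon. This is methyl in place of hydrogen on an aromatic carbon, on a six-membered aromatic ring with 1 nitrogen, two atoms from the ring nitrogen.

Neither measured step touches that place, so both offer only loose guidance. They do show that a single small group in place of hydrogen has not yet brought a change to a lower number beyond the scatter, which leaves no reason to expect a large gain in this assay. The expected result is a 1.1-fold higher number from compound 1 to compound 4 (0.05 log units; within the scatter), which means no clear change from compound 1. For compound 4 the estimated value is 25000 nM, with an expected range of 11000 nM to 50000 nM.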

Compound 4, half-maximal inhibitory concentration: 22800 nM
For compound 4 the middle estimate is 1.1-fold (0.04 log units) above the measured one, within the range that was stated.
By their numbers in this assay, from the lowest: compounds 1, 4 and 2 (each within the scatter of the next). At a limit, above all of these: compound 3.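

Methyl in place of hydrogen on the six-membered aromatic ring with 1 nitrogen gives, in this assay, a 1.0-fold higher number from compound 1 to compound 4 (0.01 log units; within the scatter). The chloro and bromo changes shown earlier lay elsewhere in the molecule, so this is the first reading at this part of the core, and it shows that one methyl group here brings no change beyond the scatter. The position therefore accepts this small carbon group with the number in this assay held level, but the step offers no gain to build on.

On these data alone, whether that holds for anything else at this position remains open, as a longer chain, an amine or a carboxylic acid could give a quite different number, and one methyl says nothing about the other carbons of that ring. Compound 3 is a limit of the assay and not a number, so the true size of the bromo step stays open as well: the limit of > 50000 nM in this assay, at which 1 of the 4 values shown sits.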